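The compounds below may be only part of what the source reports. "The series", "measured", "known", "first", "only" and "open" are said of these compounds alone.

Measured in a functional assay on HeLa cells (Homo sapiens) for inhibition, read by CCK-8 assay, with a stated time of 72 h, tested at 2 uM; a higher number here means more inhibition of growth at the concentration tested, a lower number less inhibition of growth:
- compound 1 `COc1ccc(SCc2ccc(C(=O)Nc3ccccc3N)cc2)cc1`: 35%
- compound 2 `Nc1ccccc1NC(=O)c1ccc(CSCCc2ccccc2)cc1`: 27.7%

Among the compounds with values here, compound 2 has the lower of the two numbers, but the gap to its only neighbour lies within the scatter. From the compounds shown here alone, compound 3 `Nc1ccccc1NC(=O)c1ccc(CSc2ccc(Cl)cc2)cc1` is untested and differs from compound 2 by 4-chlorophenyl in place of phenethyl on a sulfur. Within the data shown here, the one measured step at this place, phenethyl in place of 4-methoxyphenyl, is a number 7.3 percentage points lower from compound 1 to compound 2 (within the scatter). It gives no ground for expecting a change beyond the scatter, though a single step is thin evidence. The expected step is a number 5.3 percentage points higher from compound 2 to compound 3 (within the scatter). For compound 3 the estimate is 33%, with an expected range of 20% to 47%.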

Compound 3, percent growth inhibition at one concentration: 19.2%
Estimate against measurement, compound 3: 13.8 percentage points above; measured number below the stated range.
By their numbers in this assay, from the lowest: compounds 3, 2 and 1 (each within the scatter of the next, the first and the last beyond it).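

Chloro in place of methoxy on an aromatic carbon gives the first step beyond the scatter in this series, though a modest one (a number 15.8 percentage points lower from compound 1 to compound 3 (beyond the scatter)). The change of 4-chlorophenyl in place of phenethyl on a sulfur stays within the scatter (a number 8.5 percentage points lower from compound 2 to compound 3 (within the scatter)), so it does not separate these two compounds. Nothing at hand accounts for the lower number with chloro.

Open, from the compounds shown here alone, is what an amine or a carboxylic acid in place of chloro on that aromatic carbon would give. Also open, going by these compounds, is whether a longer chain in place of phenethyl on the sulfur would move the number beyond the scatter.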